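From Chlorophenyl to Chlorohydroxyphenyl: An Estimated Step

The source may hold more compounds than are shown below. What is called first, only, known or untested is meant among the compounds shown, and "the series" means these compounds.

Measured so far:
- compound 1, `COc1cc(/C=C2\CCC/C(=C\c3cccc(OC)c3OC)C2=O)cc(OC)c1`, gives 3800 nM
- compound 2, `COc1ccc(/C=C2\CCC/C(=C\c3ccccc3Cl)C2=O)cc1OC`, gives 7100 nM

Both compounds were tested in a functional assay on SW-620 cells (Homo sapiens) for cytotoxicity, read by MTT assay, with a stated time of 72 h; on this read-out lower numbers stand for stronger inhibition and higher numbers for weaker inhibition. Compound 2 has the larger of the two numbers, but its gap to compound 1 falls within the usual scatter of repeated measurements, so on these two values the compounds cannot be told apart.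

Compound 3, `COc1ccc(/C=C2\CCC/C(=C\c3ccc(O)c(Cl)c3)C2=O)cc1OC`, has not yet been measured in this assay. It differs from compound 2 in a single place: 3-chloro-4-hydroxyphenyl in place of 2-chlorophenyl on a double-bonded chain carbon bound to a double-bonded ring carbon. Among the measured compounds shown here, no pair of measured compounds shows this kind of exchange, so there is no measured step to lean on, and compound 1 differs from compound 2 in more than one place.

With nothing to guide the direction, the step in this assay from compound 2 to compound 3 is expected to be small, a 1.4-fold lower number from compound 2 to compound 3 (0.15 log units; within the scatter), and is not expected to go clearly beyond the scatter in either direction. Compound 3 is therefore estimated at 5000 nM, within a range from 1500 nM to 16000 nM.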

Compound 3, half-maximal inhibitory concentration: 7100 nM
Beside the measured number, compound 3's estimate is 1.4-fold (0.15 log units) below it, within the range that was stated.
By their numbers in this assay, from the lowest: compounds 1, 2 and 3 (each within the scatter of the next).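

In this assay the place on a double-bonded chain carbon bound to a double-bonded ring carbon now has a measured step: 3-chloro-4-hydroxyphenyl in place of 2-chlorophenyl gives no change at the digits printed from compound 2 to compound 3 (within the scatter) and thus no visible difference between the two compounds. The earlier compounds shown here could not show this, since compound 1 and compound 2 differ in more than one place. The entering group carries a hydrogen-bond donor and a hydrogen-bond acceptor that the leaving group lacks, yet this exchange leaves the read-out unchanged, and no measurement at hand speaks to what lies behind that result.

The compounds shown do not separate the hydroxy group from the chlorine, so a change from one could be offset by a change from the other, or neither could matter. Also open, going by these compounds, is whether a phenyl ring carrying an amine or a carboxylic acid at this place would shift the number beyond the scatter, or whether this place tolerates such exchanges more widely.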